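Dropping the isopropyl from compound 1

The source may hold more compounds than are shown below. What is called first, only, known or untested is meant among the compounds shown, and "the series" means these compounds.

Working notes on a set of compounds built around a shared core and tested in a functional assay on PC-3 cells (Homo sapiens) for antiproliferative activity, read by MTT assay, with a stated time of 48 h; a lower number here means a stronger inhibitor, a higher number a weaker inhibitor. Compound 1 `CC(C)c1ccc(C(=O)/C=C/c2ccc(/C=C/C(=O)NO)o2)cc1` gives 2270 nM, the lowest number among the three values recorded. Compound 3 `O=C(NO)c1ccc(/C=C/c2ccc(O)cc2)o1` gives 21800 nM, the nearest of the other two and already beyond the scatter from compound 1. Compound 2 `COc1ccc2cc(C(=O)/C=C/c3ccc(/C=C/C(=O)NO)o3)ccc2c1` gives 36300 nM, the furthest from compound 1 and also beyond the scatter. Compound 2 and compound 3 each differ from compound 1 in more than one place, so no single change can be read off between measured compounds.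

Compound 4 `O=C(/C=C/c1ccc(/C=C/C(=O)c2ccccc2)o1)NO` has not yet been measured in this assay. It differs from compound 1 by hydrogen in place of isopropyl on an aromatic carbon, on an aromatic carbon of a six-membered aromatic ring of carbon only. Going by the values given here, no measured pair isolates this change, so the expectation rests only on compound 1 holding the lowest number. The step of a 2.2-fold higher number from compound 1 to compound 4 (0.34 log units; beyond the scatter) is expected to run towards a higher number, at or somewhat beyond the scatter. For compound 4 the estimate is 5000 nM, within 2000 nM to 14000 nM.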

Compound 4, half-maximal inhibitory concentration: 13300 nM
Compound 4: middle estimate off by 2.7-fold (0.42 log units), on the low side; the measured number falls inside the stated range.
By their numbers in this assay, from the lowest: compound 1; then compounds 4, 3 and 2 (each within the scatter of the next, the first and the last beyond it).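

Hydrogen in place of isopropyl gives a 5.9-fold higher number from compound 1 to compound 4 (0.77 log units; beyond the scatter) in this assay, so the group at this position on the six-membered aromatic ring of carbon only does matter to the read-out. Going by these compounds alone, this is the first pair that differs in one place, which lets part of the lower number of compound 1 be tied to the isopropyl rather than to the shared core alone. The step shows only that the isopropyl and hydrogen differ, and no measurement shown here bears on why.

A single pair leaves open whether the isopropyl is specifically favoured or whether other groups at this place would serve as well, such as a methyl, a tert-butyl, a methoxy or an amine. It also leaves open whether the same exchange would run the same way on a different core.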